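The compounds below may be only part of what the source reports. "The series", "measured", "known", "first", "only" and "open" are said of these compounds alone.

Measured so far:
- Compound 1, `O=C1/C(=C/c2ccccc2F)CN(S(=O)(=O)c2ccc(C(F)(F)F)cc2)C/C1=C\c1ccccc1F`: in a functional assay on HepG2 cells (Homo sapiens) for cytotoxicity, read by MTT assay, with a stated time of 24 h (a higher number here means a weaker inhibitor, a lower number a stronger inhibitor), compound 1 gives 4900 nM.
- Compound 2, `O=C1/C(=C/c2ccccc2F)CN(S(=O)(=O)c2ccc(Br)cc2)C/C1=C\c1ccccc1F`: in this assay compound 2 gives 13700 nM.
- Compound 3, `Cc1ccc(S(=O)(=O)N2C/C(=C\c3ccc(F)cc3)C(=O)/C(=C/c3ccc(F)cc3)C2)cc1`: in this assay compound 3 gives 4500 nM.

Compound 3 has the lowest number of the three; it stands within the scatter of compound 1 and beyond the scatter only against compound 2. Compound 4, `N#Cc1ccc(S(=O)(=O)N2C/C(=C\c3ccc(F)cc3)C(=O)/C(=C/c3ccc(F)cc3)C2)cc1`, differs from compound 3 by cyano in place of methyl on an aromatic carbon. Within the data shown here, the only measured step at that position of the sulfonyl-bearing ring is a 2.8-fold higher number from compound 1 to compound 2 (0.45 log units; beyond the scatter), a modest step between two other groups; for methyl to cyano there is no measured step. The expected step of a 1.2-fold higher number from compound 3 to compound 4 (0.09 log units; within the scatter) is therefore small, likely within the scatter, if anything towards a higher number. For compound 4 the estimate is 5500 nM, range 2500 nM to 12000 nM.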

Compound 4, half-maximal inhibitory concentration: 9800 nM
The estimate for compound 4 lay 1.8-fold (0.25 log units) below the measured number; measured number inside the range.
By their numbers in this assay, from the lowest: compounds 3, 1, 4 and 2 (each within the scatter of the next, the first and the last beyond it).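

In this assay the change of 4-methylphenyl to 4-cyanophenyl gives a 2.2-fold higher number from compound 3 to compound 4 (0.34 log units; beyond the scatter) and so counts as a modest step beyond the scatter. This position therefore responds on the core of compound 3 too, and not only on the core of compound 1, where the step was a 2.8-fold higher number from compound 1 to compound 2 (0.45 log units; beyond the scatter) on that other core. No measurement here bears on why the number moves. Still open, as far as these compounds go, is how an amine or a carboxylic acid would read at this position. Also open, from the compounds shown here alone, is whether bromo and trifluoromethyl keep their order on the core of compound 3.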